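Bromo for chloro at the limit of the assay

The source may hold more compounds than are shown below. What is called first, only, known or untested is meant among the compounds shown, and "the series" means these compounds.

Compound 1 `CC1(C)CNC(=O)c2cc3n(c2C1)CCc1ccccc1-3` gives > 100000 nM as a limit
Compound 2 `CC1(C)CNC(=O)c2cc3n(c2C1)CCc1cc(Cl)ccc1-3` gives > 100000 nM as a limit

These entries come from a functional assay on PC-3 cells (Homo sapiens) for cytotoxicity, read by sulforhodamine B assay, with a stated time of 48 h (a higher number here means a weaker inhibitor, a lower number a stronger inhibitor), and neither is an exact number. On these data alone, compound 2 stands only at a limit, > 100000 nM, so its true position is unknown. The record so far consists of the limit of > 100000 nM in this assay, at which 2 of the 2 values shown sit, and holds no exact value.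

Compound 3 `CC1(C)CNC(=O)c2cc3n(c2C1)CCc1cc(Br)ccc1-3` differs from compound 2 in one group: bromo in place of chloro on an aromatic carbon. This puts bromo in place of chloro on an aromatic carbon, and the rest of the structure stays the same.

Within the data shown here, one measured step bears on this change. It is a step that the two limits leave unreadable from compound 1 to compound 2, in which chloro replaced hydrogen on an aromatic carbon. Its size cannot be read, and it offers no direction to carry forward, so no change beyond the usual scatter is expected in this assay. The expected step is a number no higher from compound 2 to compound 3 (the limit leaves the size open), which is an estimate without a favoured direction. For compound 3 the estimated value is 100000 nM, with an expected range from 40000 nM to 200000 nM, though the assay will most likely report only a limit.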

Compound 3, half-maximal inhibitory concentration: 33600 nM
Compound 3: middle estimate off by 3.0-fold (0.47 log units), on the high side, outside the stated range (below it).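

In this assay, among these compounds, bromo on this aromatic carbon gives the only exact value among the three compounds, and the change from chloro to bromo gives an at least 2.9-fold lower number from compound 2 to compound 3 (0.47 log units; beyond the scatter). Set against the hydrogen of the unsubstituted parent, bromo gives an at least 2.9-fold lower number from compound 1 to compound 3 (0.47 log units; beyond the scatter), so a substituent at this position can move the read-out, even though the step for chloro in place of hydrogen cannot be read. Both steps give only a smallest possible size, not a true one, because the two other compounds are known only as limits: the limit of > 100000 nM in this assay, at which 2 of the 3 values shown sit.

The compounds shown leave open whether the shift goes further with iodo, the next halogen after bromo, or whether a group of another kind on the same carbon, such as an amine, a methoxy or a nitrile, would also lower the number. They also leave open whether bromo on a different aromatic carbon of the shared core would produce a similar step, and how far compound 2 truly lies from compound 1.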